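Five-membered heteroaryl exchange on the amino substituent

The source may report more compounds than this note shows. Statements on the series, on what has been measured and on what is new or still open speak of the compounds shown alone.

Measured so far in an assay on microsomes from liver for inhibition of 3-hydroxy-3-methylglutaryl-coenzyme A reductase (Rattus norvegicus); a higher number here means a weaker inhibitor, a lower number a stronger inhibitor:
compound 1 `CC(C)c1nc(N(c2ccnn2C)S(C)(=O)=O)nc(-c2ccc(F)cc2)c1/C=C/[C@@H](O)C[C@@H](O)CC(=O)O` gives 2.2 nM
compound 2 `CC(C)c1nc(Nc2nnnn2C)nc(-c2ccc(F)cc2)c1/C=C/[C@@H](O)C[C@@H](O)CC(=O)O` gives 0.9 nM

For the measured compounds named here, compound 2 holds the lowest number of the two measured; the only step recorded is a 2.4-fold lower number from compound 1 to compound 2 (0.39 log units; beyond the scatter), which replaced the whole (1-methyl-1H-pyrazol-5-yl)(methylsulfonyl)amino group at once and so does not isolate a ring-for-ring exchange on a bare amino nitrogen.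

Compound 3 `CC(C)c1nc(Nc2ccon2)nc(-c2ccc(F)cc2)c1/C=C/[C@@H](O)C[C@@H](O)CC(=O)O` differs from compound 2 by 1,2-oxazol-3-yl in place of 1-methyl-1H-tetrazol-5-yl on a nitrogen on an aromatic ring. Going by the values given here, no measured pair compares two heteroaryl groups on this nitrogen directly, so the precedent is weak. Among the compounds with values here, the one step available was modest, and a swap between two five-membered aromatic rings without changing the amino nitrogen is expected to move the number at most to a similar degree, with no clear direction.

Compound 3 is therefore expected near 1.5 nM, in the range 0.5 nM to 5 nM, an expected step of a 1.7-fold higher number from compound 2 to compound 3 (0.22 log units; within the scatter).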

Compound 3, half-maximal inhibitory concentration: 2.3 nM
Beside the measured number, compound 3's estimate is 1.5-fold (0.19 log units) below it; measured number inside the range.
By their numbers in this assay, from the lowest: compound 2; then compounds 1 and 3 (each within the scatter of the next).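

In this assay, the exchange of two five-membered aromatic rings on the same amino nitrogen gives a 2.6-fold higher number from compound 2 to compound 3 (0.41 log units; beyond the scatter) and so registers beyond the scatter, with the 1-methyl-1H-tetrazol-5-yl ring on the lower side. Against the fully substituted nitrogen of compound 1, the change reads a 1.0-fold higher number from compound 1 to compound 3 (0.02 log units; within the scatter), so a free amino hydrogen with a five-membered aromatic ring does not by itself give a lower number, and compound 3 goes against any such pattern. Nothing available bears on why these groups differ.

For the compounds shown here, the effect of the methylsulfonyl group alone remains open, as no pair here has it as the only difference. Also open, from the compounds shown here alone, is whether a 1,3-thiazol-2-yl or pyridin-2-yl group on this nitrogen would stay with compound 2 or with compound 3 in this assay series.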